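A new chain on an amine nitrogen

The source may hold more compounds than are shown below. What is called first, only, known or untested is meant among the compounds shown, and "the series" means these compounds.

Measured in a functional assay on MV4-11 cells (Homo sapiens) for antiproliferative activity, read by CellTiter-Glo, with a stated time of 72 h (on this read-out higher numbers stand for weaker inhibition of growth and lower numbers for stronger inhibition of growth), so far
Compound 1 `CC(C)(C)OC(=O)Nc1nc(-c2cc(F)ncc2Cl)cs1` gives > 10000 nM as a limit
Compound 2 `Fc1cc(-c2csc(NCC3CCOCC3)n2)c(Cl)cn1` gives > 10000 nM as a limit
Compound 3 `O=C(N[C@H]1CC[C@H](Nc2cc(-c3csc(NCC4CCOCC4)n3)c(Cl)cn2)CC1)C1CC1` gives > 10000 nM as a limit

Compound 3 therefore stands at a limit and not at a number, as do the other two compounds. Compound 4 `COCCCN[C@H]1CC[C@H](Nc2cc(-c3csc(NCC4CCOCC4)n3)c(Cl)cn2)CC1` carries 3-methoxypropyl in place of cyclopropylcarbonyl on an amine nitrogen and awaits measurement. Within the data shown here, the only measured step that the two limits leave unreadable from compound 1 to compound 2 lies at a different nitrogen and has no readable size. All the series offers beyond that is the limit of > 10000 nM in this assay, at which 3 of the 3 values shown sit, and so the data set no size for this change. On judgment alone, the expected step is an at least 50-fold lower number from compound 3 to compound 4 (1.69 log units; beyond the scatter) towards stronger inhibition of growth. For compound 4 the estimate is 200 nM (expected range 10 nM to 5000 nM).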

Compound 4, concentration for 50% growth inhibition: 1090 nM
Beside the measured number, compound 4's estimate is 5.5-fold (0.74 log units) below it; measured number inside the range.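

In this assay, among these compounds, 3-methoxypropyl in place of cyclopropylcarbonyl on this amine nitrogen gives an at least 9.1-fold lower number from compound 3 to compound 4 (0.96 log units; beyond the scatter), so this position is the first where a change can be read. The heavy-atom count stays the same across the change, while the three-membered ring and the double bond outside aromatic rings leave. The true size of this step and the earlier step at the other nitrogen cannot be read, because of a limit: the limit of > 10000 nM in this assay, at which 3 of the 4 values shown sit.

It remains open whether the ether oxygen is needed, since a plain butyl chain is not among the compounds shown. Also open, going by these compounds, is how a longer chain or a terminal amine on this nitrogen would read.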